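The compounds below may be only part of what the source reports. "The series", "measured", "known", "first", "only" and "open" are said of these compounds alone.

Two compounds have been measured in a functional assay on the whole organism for inhibition, with Mus musculus as the target, at a dose of 25 mg/kg by the oral route; a lower number here means less inhibition, a higher number more inhibition at the dose given (going by the name of the read-out):
compound 1 `c1ccc(N2CCN(CCCCOc3ccc4c(c3)CCC4)CC2)cc1` gives 50%,
compound 2 `c1ccc(N2CCN(CCCCCOc3ccc4c(c3)CCC4)CC2)cc1` gives 25%.

Compound 1 stands highest of the two; compound 2 sits lower by a margin beyond the usual scatter. Compound 3 `Fc1cccc(N2CCN(CCCCOc3ccc4c(c3)CCC4)CC2)c1` keeps the core of compound 1 and differs from it in one place: fluoro in place of hydrogen on an aromatic carbon. Among the compounds with values here, no step of exactly this kind between measured compounds is known, and one added fluorine is a small change. In this assay a step of modest size in either direction, or none beyond the scatter, is expected. Compound 3 is expected to give 50%, with a range from 25% to 75%. The expected step is no change at the digits printed from compound 1 to compound 3 (within the scatter).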

Compound 3, a percentage reported as inhibition, in the whole organism at one dose (the size of the read-out at that dose, not a potency): 17%
Beside the measured number, compound 3's estimate is 33 percentage points above it, outside the stated range (below it).
By their numbers in this assay, from the lowest: compounds 3 and 2 (each within the scatter of the next); then compound 1.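

In this assay, the swap from phenyl to 3-fluorophenyl gives a number 33 percentage points lower from compound 1 to compound 3 (beyond the scatter). Even a single fluoro on this aromatic carbon, meta to a large group, can therefore cost much of the inhibition seen at this dose, so this position is sensitive to a very small change. Nothing at hand says why the step is so large.

Still open, on these data alone, is whether a chloro or a methoxy group at this place would give a similar step. Also open, as far as these compounds go, is whether fluoro on the other carbons of the phenyl ring would do the same.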